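Swapping a Fluorinated Ring for a Methylated One

This account rests on a few compounds, and the source may have more. Where it says the series, first, only, none or still open, it means among the compounds named here.

Measured compounds:
Compound 1, `Cc1c(CCCC(=O)O)c2cccc(/C=C/c3ccc(OCCCCc4ccccc4)cc3)c2n1CC(=O)O`, gives 4.7 nM in a functional assay on HEK293 cells for antagonist activity at cysteinyl leukotriene receptor 2 (Homo sapiens), read by fluorescence and calcium flux, with stated times of 30 min and 1 h; a lower number here means a stronger inhibitor, a higher number a weaker inhibitor.
Compound 2, `Cc1c(CCCC(=O)O)c2cccc(/C=C/c3ccc(OCCCCc4c(F)cc(F)c(F)c4F)cc3)c2n1CC(=O)O`, gives 2.2 nM in this assay.

Going by the values given here, of the two numbers known so far, compound 2 carries the lower one; the single step from the shared core, a 2.1-fold lower number from compound 1 to compound 2 (0.33 log units; beyond the scatter), puts compound 2 ahead of compound 1 by a margin beyond the scatter. Compound 3, `Cc1c(F)cccc1CCCCOc1ccc(/C=C/c2cccc3c(CCCC(=O)O)c(C)n(CC(=O)O)c23)cc1`, has not yet been measured. It differs from compound 2 in one place: 3-fluoro-2-methylphenyl in place of 2,3,4,6-tetrafluorophenyl on a saturated chain carbon, four bonds along the chain from an oxygen on an aromatic ring. Among the compounds with values here, only one measured step touches this part of the molecule, and it shows that dressing the plain ring of compound 1 with four fluorines bought a modest gain. Compound 3 keeps one fluorine but adds a methyl, so the change partly undoes what compound 2 gained. A small step in either direction, or none beyond the scatter, is expected: compound 3 is estimated at 3.3 nM, within 1.3 nM to 9 nM, which is a shift of a 1.5-fold higher number from compound 2 to compound 3 (0.18 log units; within the scatter).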

Compound 3, half-maximal inhibitory concentration: 7.2 nM
Compound 3: middle estimate off by 2.2-fold (0.34 log units), on the low side, and the stated range covers the measured number.
By their numbers in this assay, from the lowest: compound 2; then compounds 1 and 3 (each within the scatter of the next).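

In this assay, the 3-fluoro-2-methylphenyl ring does not keep what the 2,3,4,6-tetrafluorophenyl ring gained, showing a 3.3-fold higher number from compound 2 to compound 3 (0.51 log units; beyond the scatter). Set against the plain phenyl ring, the same group shows a 1.5-fold higher number from compound 1 to compound 3 (0.19 log units; within the scatter), so compound 3 cannot be told apart from compound 1, and this one methyl and one fluorine together bring neither a clear gain nor a clear loss. No measurement here explains why the rings of compound 2 and compound 3 differ.

As far as these compounds go, compound 3 carries its methyl and fluorine together, so the share of each remains open, and a ring bearing only the methyl or only the fluorine could separate them. From the compounds shown here alone, how a methoxy group, a chlorine atom or a longer chain would behave at this position is also open.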